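This account rests on a few compounds, and the source may have more. Where it says the series, first, only, none or still open, it means among the compounds named here.

In a functional assay on HepG2 cells (Homo sapiens) for inhibition, read by MTT assay, with a stated time of 72 h (on this read-out higher numbers stand for weaker inhibition and lower numbers for stronger inhibition), compound 1 (`COc1cc(O)c(CC=C(C)C)c(O)c1C(=O)/C=C/c1ccc(Cl)cc1`) gives 10100 nM, compound 2 (`COc1cc(O)c(CC=C(C)C)c(O)c1C(=O)/C=C/c1ccc([N+](=O)[O-])cc1`) gives 12400 nM and compound 3 (`COc1cc(O)c(CC=C(C)C)c(O)c1C(=O)/C=C/c1cccc([N+](=O)[O-])c1`) gives 16600 nM. The steps among them are small: a 1.2-fold higher number from compound 1 to compound 2 (0.09 log units; within the scatter), a 1.6-fold higher number from compound 1 to compound 3 (0.22 log units; within the scatter) and a 1.3-fold higher number from compound 2 to compound 3 (0.13 log units; within the scatter). Compound 1 therefore cannot be separated from the other two on these numbers.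

Compound 4 (`COc1cc(O)cc(O)c1C(=O)/C=C/c1ccc(Cl)cc1`) has not yet been measured. Its difference from compound 1 is hydrogen in place of 3-methylbut-2-en-1-yl on an aromatic carbon, ortho to two hydroxy groups and para to a methoxy group.

Among the compounds with values here, none of the measured steps touches this place. All three alter only the substituted phenyl on the double-bonded chain, and all three compounds keep the 3-methylbut-2-en-1-yl, so the series gives no direct size for this change. Compound 1 at 10100 nM is the only anchor. The change removes a whole substituent rather than exchanging one phenyl substituent for another, so a step larger than those seen so far is expected in this assay, towards a higher number, with wide uncertainty.

The expected step is a 2.5-fold higher number from compound 1 to compound 4 (0.39 log units; beyond the scatter). For compound 4 the estimated value is 25000 nM, with an expected range of 10000 nM to 60000 nM.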

Compound 4, half-maximal inhibitory concentration: 12200 nM
Compound 4: the middle estimate sits 2.0-fold (0.31 log units) above what was measured; the range from low to high includes it.
By their numbers in this assay, from the lowest: compounds 1, 4, 2 and 3 (each within the scatter of the next).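

In this assay, hydrogen in place of 3-methylbut-2-en-1-yl on the aromatic carbon ortho to two hydroxy groups and para to a methoxy group gives a 1.2-fold higher number from compound 1 to compound 4 (0.08 log units; within the scatter). Within the data shown here, the earlier compounds varied only the substituted phenyl, so this pair gives the first reading at this position: with the 4-chlorophenyl kept, a chain of 5 carbon atoms can be lost from the shared core without a step that separates compound 4 from compound 1. At this position, then, the presence or absence of the 3-methylbut-2-en-1-yl does not show up in this read-out, for this single pair. No accompanying measurement bears on this result.

From the compounds shown here alone, only the 4-chlorophenyl pair covers this change, so it remains open whether hydrogen in place of 3-methylbut-2-en-1-yl would give an equally small step with the nitrophenyl groups of compound 2 and compound 3. Also open, going by these compounds, is whether another group on this aromatic carbon, such as a methyl, an amine or a longer chain like geranyl, would move the number beyond the scatter.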